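A Methyl Added Again, Clearance Expected to Follow

A few compounds are considered here, and "the series" means these few. Any claim that something is new, unique, unknown or untested is made for them only; others in the source may bear on it.

Measured in an ADME assay on microsomes from liver (Homo sapiens) for metabolic stability, read by LC-MS, using NADPH, with a stated time of 30 min, tested at 1 uM; a higher number here means faster removal of the compound, a lower number slower removal:
- compound 1 `COCc1ccc(-c2ccc3nnc(C(N)=O)c(N[C@@H](C)c4ccn(C)n4)c3c2)cn1` gives 14 mL.min-1.g-1
- compound 2 `COCc1ccc(-c2ccc3nnc(C(N)=O)c(N[C@@H](C)c4nn(C)cc4C)c3c2)cn1` gives 31 mL.min-1.g-1
- compound 3 `C[C@H](Nc1c(C(N)=O)nnc2ccc(-c3ccc(OCCCN4CCCC4)nc3)cc12)c1ccn(C)n1` gives 10 mL.min-1.g-1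

Compound 1 and compound 2 differ by one change, (methyl in place of hydrogen on an aromatic carbon), and that change made a 2.2-fold higher number from compound 1 to compound 2 (0.35 log units; beyond the scatter). Compound 3 differs from compound 1 by 3-(pyrrolidin-1-yl)propoxy in place of methoxymethyl on an aromatic carbon, a change that made a 1.4-fold lower number from compound 1 to compound 3 (0.15 log units; within the scatter); compound 3 and compound 1 therefore cannot be set apart in this assay.

Compound 4 `Cc1cn(C)nc1[C@H](C)Nc1c(C(N)=O)nnc2ccc(-c3ccc(OCCCN4CCCC4)nc3)cc12` has not been measured. It differs from compound 3 by methyl in place of hydrogen on an aromatic carbon, the same change as from compound 1 to compound 2, at a place described in identical words, so the change is the same, only on the core of compound 3 rather than that of compound 1.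

Among the measured compounds shown here, with only one earlier example of this change, the expectation for compound 4 rests on compound 3, which gives 10 mL.min-1.g-1, and on the step of a 2.2-fold higher number from compound 1 to compound 2 (0.35 log units; beyond the scatter). The step from compound 3 to compound 4 is estimated at a 2.2-fold higher number from compound 3 to compound 4 (0.34 log units; beyond the scatter). Compound 4 is expected to show 22 mL.min-1.g-1, most likely between 12 mL.min-1.g-1 and 40 mL.min-1.g-1.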

Compound 4, intrinsic clearance in microsomes: 40 mL.min-1.g-1
The estimate for compound 4 lay 1.8-fold (0.26 log units) below the measured number, within the range that was stated.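

In this assay, the methyl on the pyrazole again gives a higher number, a 4.0-fold higher number from compound 3 to compound 4 (0.60 log units; beyond the scatter), and this step agrees with the one seen on the first core: the same change on two cores in this assay, a 2.2-fold higher number (0.35 log units; beyond the scatter) from compound 1 to compound 2 and a 4.0-fold higher number (0.60 log units; beyond the scatter) from compound 3 to compound 4, 1.8-fold (0.26 log units) apart, within the scatter of two such steps

Exchanging methoxymethyl for 3-(pyrrolidin-1-yl)propoxy gives a 1.3-fold higher number from compound 2 to compound 4 (0.11 log units; within the scatter), so compound 2 and compound 4 cannot be set apart, and this too matches the earlier result: the same change on two cores in this assay, a 1.4-fold lower number (0.15 log units; within the scatter) from compound 1 to compound 3 and a 1.3-fold higher number (0.11 log units; within the scatter) from compound 2 to compound 4, 1.8-fold (0.26 log units) apart, within the scatter of two such steps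

Each change therefore carried over between these two cores, but two pairs in one assay do not show that either step would keep its size on any other core, and they do not explain why the methyl raises the number.

On these data alone, it remains open whether an ethyl group or a fluorine atom in the place of that methyl would shift clearance in the same way. As far as these compounds go, it is also open whether a shorter chain, or a morpholine in place of the pyrrolidine, would leave the number as unchanged as 3-(pyrrolidin-1-yl)propoxy does.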